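The source may hold more compounds than are shown below. What is called first, only, known or untested is meant among the compounds shown, and "the series" means these compounds.

In an assay for inhibition of serine/threonine-protein kinase Sgk1 (Homo sapiens), with stated times of 30 min and 60 min, in the presence of a further agent that is not named here; a higher number here means a weaker inhibitor, a lower number a stronger inhibitor:
Compound 1 `CN1CCC(NC(=O)c2cc(-c3ccc(NS(=O)(=O)c4cccc(Cl)c4Cl)cc3)nc3[nH]ncc23)C1`: < 1 nM, a limit of the assay.
Compound 2 `CCN1CCC(CNC(=O)c2cc(-c3ccc(NS(=O)(=O)c4cccc(Cl)c4Cl)cc3)nc3[nH]ncc23)C1`: < 1 nM, a limit of the assay.
Compound 3 `Cc1n[nH]c2nc(-c3ccc(NS(=O)(=O)c4cc(Cl)ccc4F)cc3)nc(OC3CCOCC3)c12`: 5 nM.

For the measured compounds named here, compound 3 is the only member of the series with a numerical reading in this assay; the other two values are limits. The step from compound 1 to compound 2, a step that the two limits leave unreadable from compound 1 to compound 2, has no readable size, as the limit of < 1 nM in this assay, at which 2 of the 3 values shown sit, shows. The change now considered is 2,2,6,6-tetramethylpiperidin-4-yl in place of oxan-4-yl on an oxygen on an aromatic ring, which gives compound 4 `Cc1n[nH]c2nc(-c3ccc(NS(=O)(=O)c4cc(Cl)ccc4F)cc3)nc(OC3CC(C)(C)NC(C)(C)C3)c12`. Going by the values given here, no measured step covers this exchange: the single step between measured compounds cannot be sized, and those two compounds sit at the limit. The expectation in this assay therefore rests on compound 3 alone, and no shift beyond the usual scatter is assumed, with some room left for a somewhat stronger reading. Compound 4 is estimated at 3 nM, with a range of 0.8 nM to 12 nM. The step of a 1.7-fold lower number from compound 3 to compound 4 (0.22 log units; within the scatter) is thus expected to remain within the scatter.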

Compound 4, half-maximal inhibitory concentration: 3 nM
The estimate for compound 4 equals the measured number at the digits printed; the measured number falls inside the stated range.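

In this assay, placing 2,2,6,6-tetramethylpiperidin-4-yl in place of oxan-4-yl on an oxygen on an aromatic ring gives a 1.7-fold lower number from compound 3 to compound 4 (0.22 log units; within the scatter). For the compounds shown here, the substituent on this oxygen can therefore go from 6 to 10 heavy atoms and gain a hydrogen-bond donor with no shift beyond the scatter, and this is the only step that can be read, since the step between the two limit values cannot. Nothing measured here gives a reason for this reading.

Open, from the compounds shown here alone, is whether the four methyl groups matter, which an unsubstituted piperidin-4-yl group on the same oxygen would test. Also open, going by these compounds, is how a carboxylic acid or an open-chain amine would read at this position.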